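Methoxy to methylsulfanyl on a shared amiloride-like core

The compounds below may be only part of what the source reports. "The series", "measured", "known", "first", "only" and "open" are said of these compounds alone.

Compound 1: `NC(N)=NC(=O)c1nc(Cl)c(N2CCCCC2)nc1N`, "not determined" (no result reported) in an assay for inhibition of acid-sensing ion channel 3 (Homo sapiens), read by patch clamp, tested at 1 uM; a higher number here means more inhibition at the concentration tested (going by the name of the read-out), a lower number less inhibition.
Compound 2: `CN1CCN(c2nc(N)c(C(=O)N=C(N)N)nc2Cl)CC1`, "not determined" (no result reported) in this assay.
Compound 3: `COc1nc(N)c(C(=O)N=C(N)N)nc1Cl`, 21% in this assay.

Three compounds have been examined, but only one of them carries a number. Compound 1 and compound 2 each bear a ring on the shared core, and for both no result was reported. Going by the values given here, compound 3 carries a methoxy group at that place and is the only compound with a number in this assay, giving 21%; there is no second value to rank it against, so it stands alone.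

Compound 4, `CSc1nc(N)c(C(=O)N=C(N)N)nc1Cl`, has not been measured. It differs from compound 3 in a single place: methylsulfanyl in place of methoxy on an aromatic carbon.

Among the compounds with values here, since no measured pair in this set differs in one place, there is no observed step to guide the size of this change. The exchange keeps the count of heavy atoms and of hydrogen-bond acceptors the same, so compound 4 is expected to land close to compound 3, with a step of a number 4 percentage points higher from compound 3 to compound 4 (within the scatter) in this assay, not beyond the usual scatter in either direction. Compound 4 is therefore estimated at 25% in this assay, within a range of 5% to 50%.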

Compound 4, a percentage reported as inhibition, at one concentration (the size of the read-out at that concentration, not a potency): 12%
Compound 4: middle estimate off by 13 percentage points, on the high side, and the stated range covers the measured number.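

Going by these compounds alone, replacing methoxy with methylsulfanyl on this aromatic carbon, next to the ring nitrogen and ortho to a chloro group, gives a number 9 percentage points lower from compound 3 to compound 4 (within the scatter) in this assay and so supplies the first readable step at this position, which the earlier compounds could not provide. Because the two compounds lie within the usual scatter of each other, this exchange, which leaves the counts of heavy atoms and hydrogen-bond acceptors unchanged, cannot be told apart from no change in the inhibition read at the single tested concentration, and oxygen and sulfur cannot be ranked at this place on these data. Nothing available here explains the step or accounts for either reading.

As far as these compounds go, whether a different group at this position, such as a primary amine, an ethoxy group or a longer alkyl chain, would shift the reading beyond the scatter stays open. From the compounds shown here alone, the piperidine ring of compound 1 and the methylpiperazine ring of compound 2 carry no number, so the effect of a ring at this place also remains unknown, as does whether the exchange would behave alike with another group in place of the chloro group.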